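Notes on compound 2 and its sulfanyl ester, compound 4

The source may hold more compounds than are shown below. What is called first, only, known or untested is meant among the compounds shown, and "the series" means these compounds.

Measured in a functional assay on the whole organism (strain Hartley) for inhibition, with Cavia porcellus as the target, with stated times of 15 min and 2 min; a lower number here means that less compound is needed, a higher number that more compound is needed for the effect:
- compound 1 `CCCCC1([C@@H](O)/C=C/C2[C@H](O)CC(=O)[C@@H]2CCCCCCC(=O)O)CCC1` gives 0.03 mg/kg
- compound 2 `CCCCC1([C@H](O)/C=C/C2CCC(=O)[C@@H]2CCCCCC(=O)O)CCC1` gives 0.32 mg/kg
- compound 3 `CCCCC1([C@@H](O)/C=C/C2CCC(=O)[C@@H]2CCCCCCC(=O)OCC)CCC1` gives 0.00206 mg/kg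

Compound 2 has the highest number of the three, with compound 1 nearest and compound 3 furthest, both gaps beyond the scatter. The change to compound 4 `CCCCC1([C@H](O)/C=C/C2CCC(=O)[C@@H]2CCCCSCC(=O)OCC)CCC1` is ((ethoxycarbonyl)methyl)sulfanyl in place of carboxymethyl on a saturated chain carbon, four bonds along the chain from a saturated ring carbon, on a saturated chain carbon, four bonds along the chain from a saturated ring carbon. Among the compounds with values here, compound 3 also ends in ethoxycarbonyl and gives 0.00206 mg/kg in this assay, but no sulfanyl compound has been measured and compound 3 is no close match. A move to a lower number, beyond the scatter, is therefore expected, with the estimated step of an 8.0-fold lower number from compound 2 to compound 4 (0.90 log units; beyond the scatter) as the working figure. For compound 4 the expected value is 0.04 mg/kg, with an estimated range of 0.005 mg/kg to 0.3 mg/kg in this series.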

Compound 4, dose for half-maximal effect: 0.909 mg/kg
Compound 4: middle estimate off by 23-fold (1.36 log units), on the low side; the measured number lies above the stated range.
By their numbers in this assay, from the lowest: compound 3; then compound 1; then compound 2; then compound 4.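

In this assay, ((ethoxycarbonyl)methyl)sulfanyl in place of carboxymethyl gives a 2.8-fold higher number from compound 2 to compound 4 (0.45 log units; beyond the scatter), the first step read at this position on a saturated chain carbon. The change is therefore modest in size, but it goes against lower numbers for this pair. Nothing at hand accounts for the step.

The change brings in the sulfanyl link and the ethyl ester together, so their separate shares remain unresolved. A free carboxylic acid on the sulfanyl chain, as (carboxymethyl)sulfanyl, would divide the step between them.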